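Dechlorination step across two cores, one measured, one pending

The source may hold more compounds than are shown below. What is called first, only, known or untested is meant among the compounds shown, and "the series" means these compounds.

compound 1 `COc1cc2c(cc1OC)C(c1ccccc1)=NNC(=O)C2`: 33.9 umol/kg in a functional assay on the whole organism with Mus musculus as the target; on this read-out lower numbers stand for an effect already at smaller amounts and higher numbers for an effect only at larger amounts of compound
compound 2 `COc1cc2c(cc1OC)C(c1ccc(Cl)cc1)=NN=C(S)C2`: 82.4 umol/kg in this assay
compound 3 `COc1cc2c(cc1OC)C(c1ccc(Cl)cc1)=NNC(=O)C2`: 102 umol/kg in this assay

Compound 3 and compound 1 differ by hydrogen in place of chloro on an aromatic carbon. This change gives a 3.0-fold lower number from compound 3 to compound 1 (0.48 log units; beyond the scatter). The difference between the core of compound 3 and the core of compound 2 is not broken down here; their values in this assay lie within the scatter of each other. Compound 4 `COc1cc2c(cc1OC)C(c1ccccc1)=NN=C(S)C2` is not yet measured; it differs from compound 2 by hydrogen in place of chloro on an aromatic carbon, the same change at the same place as between compound 3 and compound 1, now on the core of compound 2. As far as these compounds go, the step from compound 2 to compound 4 in this assay is expected to be a 2.9-fold lower number from compound 2 to compound 4 (0.47 log units; beyond the scatter), because the same change gave a 3.0-fold lower number from compound 3 to compound 1 (0.48 log units; beyond the scatter) on the other core; whether it carries over to this core is untested. Compound 4 is therefore estimated at 28 umol/kg in this assay, with a range from 12 umol/kg to 65 umol/kg.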

Compound 4, dose for half-maximal effect: 19.7 umol/kg
Compound 4: middle estimate off by 1.4-fold (0.15 log units), on the high side, and the stated range covers the measured number.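

The change from 4-chlorophenyl to phenyl gives a 4.2-fold lower number from compound 2 to compound 4 (0.62 log units; beyond the scatter) in this assay. On both cores the number falls with this change, and the two steps agree in size within the scatter: the same change on two cores in this assay, a 3.0-fold lower number (0.48 log units; beyond the scatter) from compound 3 to compound 1 and a 4.2-fold lower number (0.62 log units; beyond the scatter) from compound 2 to compound 4, 1.4-fold (0.14 log units) apart, within the scatter of two such steps

This supports carrying the change between these two cores only; it rests on two pairs, and it shows neither why the number falls nor whether the step holds on any further core.

Open, as far as these compounds go, is how other groups at the same place on the phenyl ring, such as fluoro, methoxy or an amine, compare with hydrogen and chloro on either core.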